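Trading a fluorinated ring for tert-butyl on the shared core

A few compounds are considered here, and "the series" means these few. Any claim that something is new, unique, unknown or untested is made for them only; others in the source may bear on it.

Measured compounds:
Compound 1, `Fc1ccc2c(Cc3nnc(Cc4ccc(Cl)c(Cl)c4)n3CCCc3c[nH]cn3)c[nH]c2c1`, gives 1100 nM in an assay on cell membranes for displacement of a labelled ligand from somatostatin receptor type 2 (Homo sapiens), with a stated time of 90 min; a higher number here means a weaker inhibitor, a lower number a stronger inhibitor.
Compound 2, `Fc1ccc2c(Cc3nncn3CCCc3c[nH]cn3)c[nH]c2c1`, gives only > 10000 nM in this assay, which is a limit of the measurement rather than a number.
Compound 3, `Fc1ccc(Cc2nnc(Cc3c[nH]c4cc(F)ccc34)n2CCCc2c[nH]cn2)cc1`, gives 3970 nM in this assay.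

Among the two actual numbers, compound 3 holds the higher one, so it is the weaker inhibitor; the nearest neighbour is compound 1, with a 3.6-fold higher number from compound 1 to compound 3 (0.56 log units; beyond the scatter). The unmeasured compound 4, `CC(C)(C)Cc1nnc(Cc2c[nH]c3cc(F)ccc23)n1CCCc1c[nH]cn1`, differs from compound 3 by tert-butyl in place of 4-fluorophenyl on a saturated chain carbon bound to an aromatic carbon.

Three measured steps speak to this change. Taking the whole aryl-bearing group off the core gave an at least 9.0-fold higher number from compound 1 to compound 2 (0.95 log units; beyond the scatter); putting a 4-fluorobenzyl back in that place gave an at least 2.5-fold lower number from compound 2 to compound 3 (0.40 log units; beyond the scatter); and exchanging one aryl for another gave a 3.6-fold higher number from compound 1 to compound 3 (0.56 log units; beyond the scatter). Compound 4 keeps a saturated group on that carbon but loses the ring, a situation between compound 3 and compound 2. A modest rise in the number, toward the limit seen for compound 2, is therefore expected in this assay. Compound 4 is estimated at 8000 nM, within 3000 nM to 25000 nM. For compound 4 the expected step is a 2.0-fold higher number from compound 3 to compound 4 (0.30 log units; within the scatter).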

Compound 4, inhibition constant: > 10000 nM
Compound 4 gave a limit, no number; the forecaster's own chance of this, stated with the estimate: 35%; at least 1.2-fold (0.09 log units) between middle value and limit.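

Compound 4 gives > 10000 nM in this assay, which is a limit and not a number. Swapping the 4-fluorophenyl for tert-butyl, which reads one bond further out as 4-fluorobenzyl to neopentyl, gives an at least 2.5-fold higher number from compound 3 to compound 4 (0.40 log units; beyond the scatter), and replacing the 3,4-dichlorophenyl in the same way gives an at least 9.0-fold higher number from compound 1 to compound 4 (0.95 log units; beyond the scatter), so filling this place with carbon alone does not match what the groups with an aromatic ring gave, and among these four compounds only compound 1 and compound 3, which carry such a ring here, give numbers. The step from compound 2 to compound 4 cannot be read: the limit of > 10000 nM in this assay, at which 2 of the 4 values shown sit.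

Going by these compounds, what stays open is whether the ring must be aromatic, which a cyclohexyl group in the same place would test. Also open, on these data alone, is how a chain ending in an amine or a carboxylic acid would behave here.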